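Triazole series: nitro to chloro on the aryl ring

The source may report more compounds than this note shows. Statements on the series, on what has been measured and on what is new or still open speak of the compounds shown alone.

Measured in a functional assay on A549 cells (Homo sapiens) for antiproliferative activity, read by MTT assay, with a stated time of 72 h; a higher number here means a weaker inhibitor, a lower number a stronger inhibitor:
- compound 1 `COc1cc(-c2ncnn2-c2cccc(F)c2)cc(OC)c1OC`: > 10000 nM (a limit)
- compound 2 `COc1cc(-c2ncnn2-c2ccc(Cl)cc2Cl)cc(OC)c1OC`: > 10000 nM (a limit)
- compound 3 `COc1cc(-c2ncnn2-c2ccc([N+](=O)[O-])cc2)cc(OC)c1OC`: > 10000 nM (a limit)

Compound 3 is known only by a limit, with no number behind it. The other two compounds are in the same position: the limit of > 10000 nM in this assay, at which 3 of the 3 values shown sit.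

Compound 4 `COc1cc(-c2ncnn2-c2ccc(Cl)cc2)cc(OC)c1OC` has chloro in place of nitro on an aromatic carbon, para to a large group: chloro in place of nitro on an aromatic carbon.

Among the compounds with values here, the only measured step that bears on this change is a step that the two limits leave unreadable from compound 1 to compound 2, and it has no readable size. Within the data shown here, it therefore gives no basis for a step of any particular size or direction, and the expectation rests on all three compounds sitting at the same limit. No step beyond the scatter is expected in this assay, and the estimated step is a number no higher from compound 3 to compound 4 (the limit leaves the size open). A further limit is the most likely result. For compound 4 the expected value is 10000 nM, with an estimated range from 3000 nM to 30000 nM.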

Compound 4, half-maximal inhibitory concentration: > 10000 nM
Compound 4 gave a limit, no number (the forecaster's own chance of this, stated with the estimate: 75%); the middle value lies on the limit itself.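

Compound 4 gives only a limit, > 10000 nM, in this assay. No step linking compound 4 with compound 1, compound 2 or compound 3 can be read, because all four compounds share that limit: the limit of > 10000 nM in this assay, at which 4 of the 4 values shown sit.

The compounds shown leave open whether these aryl groups differ at all in this assay.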